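A few compounds are considered here, and "the series" means these few. Any claim that something is new, unique, unknown or untested is made for them only; others in the source may bear on it.

Compound 1, `CCOc1ncc(-c2nc(C(F)(F)F)sc2N2CCN(C(=O)Cn3nccc3C)[C@H](C)C2)cn1`, in a functional assay on U2OS cells for antagonist activity at C-X-C chemokine receptor type 3 (Homo sapiens), read by beta-arrestin recruitment (a higher number here means a weaker inhibitor, a lower number a stronger inhibitor), gives 162 nM.
Compound 2, `CCOc1ncc(-c2nc(C(F)(F)F)sc2N2CCN(C(=O)Cn3nc(C)cc3C)[C@H](C)C2)cn1`, gives 87 nM.
Compound 3, `CCOc1ncc(-c2nc(C(F)(F)F)sc2N2CCN(C(=O)Cn3nc(C)nc3C)[C@H](C)C2)cn1`, gives 173 nM.

Compound 3 has the highest of the three numbers, yet the steps of a 1.1-fold higher number from compound 1 to compound 3 (0.03 log units; within the scatter) and a 2.0-fold higher number from compound 2 to compound 3 (0.30 log units; within the scatter) both lie within the scatter, so the three cannot be ordered. Compound 4 is `CCOc1ncc(-c2nc(C(F)(F)F)sc2N2CCN(C(=O)Cn3cnc(C(F)(F)F)n3)[C@H](C)C2)cn1`; it differs from compound 3 by 3-(trifluoromethyl)-1H-1,2,4-triazol-1-yl in place of 3,5-dimethyl-1H-1,2,4-triazol-1-yl on a saturated chain carbon bound to a carbonyl carbon. Going by the values given here, the steps that bear on this place are the ring swaps a 1.1-fold higher number from compound 1 to compound 3 (0.03 log units; within the scatter) and a 2.0-fold higher number from compound 2 to compound 3 (0.30 log units; within the scatter) and the methyl addition a 1.9-fold lower number from compound 1 to compound 2 (0.27 log units; within the scatter), all within the scatter. Among the compounds with values here, no measured step covers a trifluoromethyl on this ring. Compound 4 is therefore expected to give about 170 nM, between 70 nM and 420 nM, a step of a 1.0-fold lower number from compound 3 to compound 4 (0.01 log units; within the scatter) expected to stay within the scatter.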

Compound 4, half-maximal inhibitory concentration: 118 nM
Compound 4: middle estimate off by 1.4-fold (0.16 log units), on the high side; the measured number falls inside the stated range.
By their numbers in this assay, from the lowest: compounds 2, 4, 1 and 3 (each within the scatter of the next).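

In this assay, the 3-(trifluoromethyl)-1H-1,2,4-triazol-1-yl group is accepted on this saturated chain carbon: a 1.5-fold lower number from compound 3 to compound 4 (0.17 log units; within the scatter), a 1.4-fold higher number from compound 2 to compound 4 (0.13 log units; within the scatter) and a 1.4-fold lower number from compound 1 to compound 4 (0.14 log units; within the scatter) all stay within the scatter. The four rings shown on this carbon, now including one bearing trifluoromethyl rather than methyl, therefore give numbers that cannot be told apart. No measurement here offers an explanation for this result.

From the compounds shown here alone, it remains open whether an amine, a carboxylic acid or a phenyl ring on this carbon would shift the number beyond the scatter. Going by these compounds, the separate contribution of each methyl on the 3,5-dimethyl-1H-1,2,4-triazol-1-yl ring also remains open.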